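Dropping One Chloro from the Dichlorophenoxy Sulfonamide

The source may hold more compounds than are shown below. What is called first, only, known or untested is meant among the compounds shown, and "the series" means these compounds.

Compound 1 `O=C(Oc1ccc([N+](=O)[O-])cc1)N1CCN(S(=O)(=O)c2ccc(-c3ccc(Cl)c(Cl)c3)cc2)CC1` and compound 2 `O=C(Oc1ccc([N+](=O)[O-])cc1)N1CCN(S(=O)(=O)c2ccc(Oc3ccc(Cl)c(Cl)c3)cc2)CC1` share the same core and differ only in how the dichlorinated ring is attached. In an assay on isolated protein for inhibition of Fatty-acid amide hydrolase 1 (Homo sapiens), read by fluorescence (a higher number here means a weaker inhibitor, a lower number a stronger inhibitor), compound 1 gives 382 nM, and compound 2 gives 317 nM. The step of a 1.2-fold lower number from compound 1 to compound 2 (0.08 log units; within the scatter) falls within the scatter, so compound 2 stands at the lower of the two numbers seen so far without being separable from compound 1.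

Compound 3 `O=C(Oc1ccc([N+](=O)[O-])cc1)N1CCN(S(=O)(=O)c2ccc(Oc3ccc(Cl)cc3)cc2)CC1` is the unmeasured partner of compound 2: hydrogen in place of chloro on an aromatic carbon. Put another way, the 3,4-dichlorophenoxy group becomes a 4-chlorophenoxy group.

Going by the values given here, no measured step bears directly on this change; the one step available, from compound 1 to compound 2, alters the link between the rings and leaves both chloro groups in place. In the absence of a direct precedent, the expectation is that removing a chloro gives a modest rise in this assay, expressed as the step of a 1.7-fold higher number from compound 2 to compound 3 (0.24 log units; within the scatter). Compound 3 is therefore estimated at 550 nM, with a range from 220 nM to 1400 nM.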

Compound 3, half-maximal inhibitory concentration: 153 nM
Beside the measured number, compound 3's estimate is 3.6-fold (0.56 log units) above it; the measured number lies below the stated range.
By their numbers in this assay, from the lowest: compound 3; then compounds 2 and 1 (each within the scatter of the next).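

In this assay, replacing the chloro group with hydrogen on the aromatic carbon ortho to a chloro group and meta to a large group gives a 2.1-fold lower number from compound 2 to compound 3 (0.32 log units; beyond the scatter) and so turns the 3,4-dichlorophenoxy group into a 4-chlorophenoxy group that inhibits more strongly, with a step beyond the scatter where the change of link alone gave none. The same compound also separates from the other dichlorinated partner, with a 2.5-fold lower number from compound 1 to compound 3 (0.40 log units; beyond the scatter) as the step, which leaves compound 3 with the lowest number of the three, though this rests on a single pair for the chloro change and says nothing yet of other rings. No measurement at hand accounts for the direction of this step.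

The compounds shown leave open whether a plain phenoxy group, with the remaining chloro also replaced by hydrogen, would lower the number further or raise it, and whether a fluoro or methoxy group on the emptied carbon would act as hydrogen does. They also leave open whether the same change on the 3,4-dichlorophenyl group of compound 1, giving a 4-chlorophenyl group, would produce a step of similar size.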